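A few compounds are considered here, and "the series" means these few. Any claim that something is new, unique, unknown or untested is made for them only; others in the source may bear on it.

Compound 1 `COc1ccc2c(c1)C[C@H](C(=O)Nc1ccc(-c3cn[nH]c3)cc1O[C@@H]1CCN(C)C1)CO2`: 261 nM
Compound 2 `COc1ccc2c(c1)C[C@H](C(=O)Nc1ccc(-c3cn[nH]c3)cc1O[C@H]1CCN(C)C1)CO2`: 294 nM
Compound 3 `COc1ccc2c(c1)C[C@@H](C(=O)Nc1ccc(-c3cn[nH]c3)cc1OCCCO)CO2`: "not determined" (no result reported)

In an assay on isolated protein for inhibition of serine/threonine-protein kinase MRCK alpha (Homo sapiens), read by luminescence, with a stated time of 75 min (a lower number here means a stronger inhibitor, a higher number a weaker inhibitor), compound 1 gives 261 nM and compound 2 gives 294 nM. The step of a 1.1-fold higher number from compound 1 to compound 2 (0.05 log units; within the scatter) rests on (the fact that compounds 1 and 2 differ only in the configuration as drawn), so the change of configuration at that saturated ring carbon leaves the number within the scatter. For compound 3 this assay reports "not determined" (no result reported), so compound 3 cannot be placed on the numbers shown.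

Compound 4 `COc1ccc2c(c1)C[C@H](C(=O)Nc1ccc(-c3cn[nH]c3)cc1OCCCO)CO2` differs from compound 3 in one way: the two compounds have the same atoms and bonds and differ only in configuration as drawn: 1 of 1 stereo elements differ; a stereocentre at a saturated ring carbon is drawn R in compound 3 and S in compound 4. Going by the values given here, the only measured step that bears on a change of configuration is the one from compound 1 to compound 2, and it was within the scatter; but that step concerns a different ring carbon, and compound 3 has no number from which to step. Nothing therefore fixes the direction or size of the change in this assay for compound 4, and only the range seen for compounds 1 and 2 gives a rough anchor.

Compound 4 is therefore estimated at 400 nM, expected to lie between 80 nM and 2500 nM.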

Compound 4, half-maximal inhibitory concentration: 74 nM
For compound 4 the middle estimate is 5.4-fold (0.73 log units) above the measured one; measured number outside the range, below it.
By their numbers in this assay, from the lowest: compound 4; then compounds 1 and 2 (each within the scatter of the next).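

Compound 4 shows that the group on this oxygen matters in this assay where the configuration within it did not: 3-hydroxypropyl in place of 1-methylpyrrolidin-3-yl on an oxygen on an aromatic ring gives a 4.0-fold lower number from compound 2 to compound 4 (0.60 log units; beyond the scatter) and also a 3.5-fold lower number from compound 1 to compound 4 (0.55 log units; beyond the scatter) and both steps lie beyond the scatter. The earlier pair had shown only a 1.1-fold higher number from compound 1 to compound 2 (0.05 log units; within the scatter) and so gave no sign that this position could move the number at all. The change is modest in size, yet it needs no 1-methylpyrrolidin-3-yl group, and compound 4 has the lowest number of the compounds measured.

From the compounds shown here alone, whether a longer chain, a carboxylic acid or an open-chain amine on this oxygen would lower the number further remains open. The step from compound 3 to compound 4 cannot be read, so the effect of configuration at the saturated ring carbon of the core is unknown, and that pair would isolate it: the fact that compounds 3 and 4 differ only in the configuration as drawn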